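This account rests on a few compounds, and the source may have more. Where it says the series, first, only, none or still open, it means among the compounds named here.

Of the compounds shown here, three sharing one core have been measured in an assay on Sf9 cells for inhibition of serine/threonine-protein kinase 4 (Homo sapiens), read by luminescence and ADP-Glo, with a stated time of 1 h, in the presence of a further agent that is not named here; a higher number here means a weaker inhibitor, a lower number a stronger inhibitor. Compound 1 `CCCC1C(=O)N(C)c2cnc(Nc3ccc(S(N)(=O)=O)cc3)nc2N1C` gives 206 nM, compound 2 `CC(C)CC1C(=O)N(C)c2cnc(Nc3ccc(S(N)(=O)=O)cc3)nc2N1C` gives 77 nM, and compound 3 `CN1C(=O)C(c2ccccc2F)N(C)c2nc(Nc3ccc(S(N)(=O)=O)cc3)ncc21` gives 75 nM. On these numbers compound 2 stands second highest of the three: its nearest neighbour is compound 3, with a 1.0-fold lower number from compound 2 to compound 3 (0.01 log units; within the scatter), and its furthest is compound 1, with a 2.7-fold lower number from compound 1 to compound 2 (0.43 log units; beyond the scatter). Compound 4 `CN1C(=O)C(Cc2ccccc2)N(C)c2nc(Nc3ccc(S(N)(=O)=O)cc3)ncc21` has not yet been measured. It differs from compound 2 in one place: phenyl in place of isopropyl on a saturated chain carbon bound to a saturated ring carbon. Among the compounds with values here, two measured steps bear on this change. The step of a 1.0-fold lower number from compound 2 to compound 3 (0.01 log units; within the scatter) replaces a chain with an aromatic ring on the saturated ring carbon and lies within the scatter, while the step of a 2.7-fold lower number from compound 1 to compound 3 (0.44 log units; beyond the scatter) makes the same kind of exchange from a shorter chain and is modest. Compound 4 is therefore expected to show a step of a 1.1-fold lower number from compound 2 to compound 4 (0.04 log units; within the scatter) in this assay, staying near compound 2. The estimate for compound 4 is 70 nM, with a range from 30 nM to 160 nM.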

Compound 4, half-maximal inhibitory concentration: > 10000 nM
Compound 4: no number, only a limit (the forecaster's own chance of this, stated with the estimate: 2%); middle value at least 140-fold (2.15 log units) from the limit.
By their numbers in this assay, from the lowest: compounds 3 and 2 (each within the scatter of the next); then compound 1. At a limit, above all of these: compound 4.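

In this assay, compound 4 gives no number, only a limit: the limit of > 10000 nM in this assay, at which 1 of the 4 values shown sits.

The change from isobutyl to benzyl therefore produces large steps, an at least 120-fold higher number from compound 2 to compound 4 (2.11 log units; beyond the scatter), and the same holds for an at least 130-fold higher number from compound 3 to compound 4 (2.12 log units; beyond the scatter) and an at least 48-fold higher number from compound 1 to compound 4 (1.68 log units; beyond the scatter). Compound 3 also carries an aromatic ring at this part of the molecule, directly on the saturated ring carbon, so an aromatic ring alone does not go with the loss, which appears here only with the phenyl on a saturated chain carbon bound to a saturated ring carbon.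

The compounds shown leave open whether the aromatic character of that phenyl matters or only its place and size, which a cyclohexylmethyl group could separate. They also leave open whether a chain ending in an amine or a carboxylic acid is accepted at this position, and how far compound 4 lies past its limit.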